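A few compounds are considered here, and "the series" means these few. Any claim that something is new, unique, unknown or untested is made for them only; others in the source may bear on it.

Compound 1, `CCSC(=S)SCC(=O)c1cccc(OC)c1`: 5010 nM. Compound 2, `CCSC(=S)SCC(=O)c1ccc(Cl)c(Cl)c1`: 7940 nM. Compound 3, `Cc1ccc(C(=O)CSC(=S)SC(C)(C)C)cc1`: 31600 nM.

These three compounds were tested in a functional assay on HeLa cells (Homo sapiens) for antiproliferative activity, read by resazurin assay; on this read-out lower numbers stand for stronger inhibition and higher numbers for weaker inhibition. Compound 1 gives the lowest number of the three, although compound 2 sits within the usual scatter of repeated measurements of it, so the two cannot be told apart on these data; compound 3 lies beyond that scatter. The compound that remains to be measured is compound 4, `CCSC(=S)SCC(=O)c1ccc(OC)c(OC)c1`. Compared with compound 1 it differs in one place: methoxy in place of hydrogen on an aromatic carbon. Among the measured compounds shown here, no pair of measured compounds differs by this change alone, so nothing in the data fixes its size or direction. The account therefore expects a step of a 1.2-fold higher number from compound 1 to compound 4 (0.08 log units; within the scatter) in this assay, that is, none beyond the scatter, with no direction claimed. For the measured compounds named here, on this basis compound 4 is estimated at 6000 nM, in a range from 2000 nM to 20000 nM, with the wide range reflecting that the change has no measured counterpart among the three compounds.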

Compound 4, half-maximal inhibitory concentration: 5010 nM
Compound 4: the middle estimate sits 1.2-fold (0.08 log units) above what was measured, within the range that was stated.
By their numbers in this assay, from the lowest: compounds 1, 4 and 2 (each within the scatter of the next); then compound 3.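

In this assay, placing methoxy in place of hydrogen on an aromatic carbon, ortho to a methoxy group and para to a group of 9 heavy atoms, gives no change at the digits printed from compound 1 to compound 4 (within the scatter). Among the compounds shown here, this is the first step between measured compounds that differ in one place, and it shows that, on the core of compound 1, this position takes the added methoxy without a shift beyond the scatter. Nothing available explains why the read-out stays level at this position.

The compounds shown leave open whether a larger or differently built group at this position, such as an amine, a carboxylic acid or a longer alkoxy chain, would also leave the number level. They also leave open whether the same methoxy would behave this way on a core without the neighbouring methoxy group of compound 1.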